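The source may hold more compounds than are shown below. What is called first, only, known or untested is meant among the compounds shown, and "the series" means these compounds.

Compound 1 `C/C(=C\c1cc(-c2ccc(C)cc2)cs1)C(N)=O` is the reference point of the series. In an ADME assay on NIH3T3 cells (Mus musculus) for cytotoxicity, read by CCK-8 assay, with a stated time of 24 h (a lower number here means a stronger inhibitor, a higher number a weaker inhibitor), compound 1 returns only a limit of > 50000 nM and not a number. Going by the values given here, compound 2 `C/C(=C\c1nc(-c2ccc(F)cc2)cs1)C(N)=O` is the only other measured member. In this assay compound 2 likewise returns a limit of > 50000 nM rather than a number. Among the compounds with values here, both measured entries sit at the limit of > 50000 nM in this assay, at which 2 of the 2 values shown sit, so compound 1 stands at the assay limit and not at a defined value, and no step between measured compounds can be computed. Compound 3 `C/C(=C\c1cc(-c2ccc(Cl)cc2)cs1)C(N)=O` carries the change chloro in place of methyl on an aromatic carbon on an aromatic carbon of a six-membered aromatic ring of carbon only. Nothing measured bears on this change, so no step beyond the usual scatter is expected in this assay in either direction. Compound 3 is therefore expected to remain at the limit, with an estimate of 60000 nM spanning 30000 nM to 150000 nM and the implied step that the limit leaves unreadable from compound 1 to compound 3 expected to be within scatter.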

Compound 3, half-maximal inhibitory concentration: > 50000 nM
Compound 3 gave a limit, no number (the forecaster's own chance of this, stated with the estimate: 80%); the middle value does not contradict the limit.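

Going by these compounds alone, compound 3, like compound 1, returns a limit and not a number in this assay, so no step for chloro in place of methyl on an aromatic carbon can be read: the limit of > 50000 nM in this assay, at which 3 of the 3 values shown sit. The compounds shown leave open whether any change to the shared core gives a defined value in this assay at all.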